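Dropping an Ethyl Group from a Weak Inhibitor

The source may report more compounds than this note shows. Statements on the series, on what has been measured and on what is new or still open speak of the compounds shown alone.

Three compounds have been examined in an assay on cells for inhibition of S-adenosylmethionine decarboxylase proenzyme (Homo sapiens), read by mass spectrometry, at pH 7.2; a lower number here means a stronger inhibitor, a higher number a weaker inhibitor. Compound 1 `Cc1cc(N)cc(Nc2cc(Cl)cc(Cl)c2)n1` gives > 180000 nM, which is a limit of the assay rather than a number. Compound 3 `Cc1cc(Nc2cc(C(C)(C)C)cc(C(C)(C)C)c2)nc(N)n1` gives > 63000 nM, again only a limit. Compound 2 `CCc1cc(Br)cc(Nc2cc(C)nc(N)n2)c1` gives > 180000 nM in this assay, and this too is a limit. Going by the values given here, compound 2 thus stands at the limit of > 180000 nM in this assay, at which 2 of the 3 values shown sit, and compound 3 sits at the limit of > 63000 nM in this assay, at which 1 of the 3 values shown sits; none of the three has yielded a measurable number, so no step between measured compounds can be drawn.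

Compound 4 `Cc1cc(Nc2cccc(Br)c2)nc(N)n1` differs from compound 2 by hydrogen in place of ethyl on an aromatic carbon. Because compound 2 gives > 180000 nM, only a limit, the change is expected to leave compound 4 in the same region, with no step beyond the scatter in this assay. The implied step, a step that the limit leaves unreadable from compound 2 to compound 4, is expected to be nothing beyond the scatter. Compound 4 is estimated to give about 200000 nM in this assay, within a range from 60000 nM to 600000 nM, most probably reported as a limit once more.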

Compound 4, half-maximal inhibitory concentration: > 180000 nM
Compound 4: only a limit was reported; the forecaster's own chance of this, stated with the estimate: 85%; the middle value is on the limit's open side.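

Compound 2 and compound 4 are both reported only as limits, so the step between them, hydrogen in place of ethyl on an aromatic carbon, cannot be read in this assay. The compounds shown leave open whether removing the ethyl group changes inhibition at all, as every value shown is a limit, most of them the same one: the limit of > 180000 nM in this assay, at which 3 of the 4 values shown sit.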